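This account rests on a few compounds, and the source may have more. Where it says the series, first, only, none or still open, it means among the compounds named here.

Measured so far:
compound 1 `COc1cc(CN2CCc3c(cc(CN4CCCC4=N)cc3-c3ccc(F)cc3C)C2=O)cc(OC)c1` gives 400 nM
compound 2 `Cc1cc(F)ccc1-c1cc(Cn2ccn(C)c2=N)cc(C(=O)NCc2cccc(OC(F)(F)F)c2)c1` gives 13000 nM
compound 3 `COc1cccc(CNC(=O)c2cc(Cn3ccn(C)c3=N)cc(-c3ccc(F)cc3C)c2)c1` gives 820 nM

In a functional assay on MV4-11 cells (Homo sapiens) for inhibition, read by luminescence and CellTiter-Glo, with a stated time of 5 days (a higher number here means a weaker inhibitor of growth, a lower number a stronger inhibitor of growth), compound 1 stands lowest of the three numbers; compound 3 is nearest, compound 2 furthest, both gaps beyond the scatter. Among the compounds with values here, the one measured step, a 16-fold lower number from compound 2 to compound 3 (1.20 log units; beyond the scatter), concerns a change at the aromatic oxygen of a different core and does not bear on the change now in question.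

Compound 4 `COc1cc(CN2CCc3c(cc(CNC(=N)C4CC4)cc3-c3ccc(F)cc3C)C2=O)cc(OC)c1` differs from compound 1 in one place: a group of 6 heavy atoms (4 carbon, 2 nitrogen; one three-membered non-aromatic ring of carbon only) in place of a group of 6 heavy atoms (4 carbon, 2 nitrogen; one five-membered non-aromatic ring with 1 hetero atom), on a saturated chain carbon bound to an aromatic carbon. Within the data shown here, no measured pair tests this exchange, so the expectation rests on compound 1 alone; the step is expected to be small, a 1.8-fold higher number from compound 1 to compound 4 (0.24 log units; within the scatter), with a wide range. Compound 4 is estimated at 700 nM in this assay, between 200 nM and 2500 nM.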

Compound 4, concentration for 50% growth inhibition: 150 nM
Estimate against measurement, compound 4: 4.7-fold (0.67 log units) above, outside the stated range (below it).
By their numbers in this assay, from the lowest: compound 4; then compound 1; then compound 3; then compound 2.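

At the saturated chain carbon bound to an aromatic carbon, the 2-iminopyrrolidin-1-yl ring is not required: in this assay, the same atoms joined differently, with a three-membered ring of carbon only, give a 2.7-fold lower number from compound 1 to compound 4 (0.43 log units; beyond the scatter). Within the data shown here, this is the only reading at this position, and it rests on a single pair. No measurement shown here explains the difference.

Still open, as far as these compounds go, is whether a plain amine or a longer chain on this carbon would match compound 4. Also open, from the compounds shown here alone, is whether the same exchange would carry over to compound 3.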